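Swapping acetyl for dimethylamino on a cytotoxic pyrazole series

A few compounds are considered here, and "the series" means these few. Any claim that something is new, unique, unknown or untested is made for them only; others in the source may bear on it.

Of the compounds shown here, two have been measured in a functional assay on CAKI-1 cells (Homo sapiens) for cytotoxicity, read by sulforhodamine B assay, with a stated time of 48 h, tested at 100 nM; a lower number here means a stronger effect, a higher number a weaker effect of the compound at the concentration tested. Compound 1 `COc1cc(C)cc(-c2c(-c3ccnc(-c4ccc(C(C)=O)cc4)c3)cnn2CC#N)c1` gives 86%, the higher of the two numbers, which means a weaker effect at the tested concentration. Compound 2 `COc1cc(C)cc(-c2nn(CC#N)cc2-c2ccnc(-c3ccc(N(C)C)cc3)c2)c1` gives 14%, a number far lower, and the gap between these two values lies beyond the usual scatter. Within the data shown here, compound 2 differs from compound 1 in more than one place, so no single step can be drawn between them.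

Compound 3 `COc1cc(C)cc(-c2c(-c3ccnc(-c4ccc(N(C)C)cc4)c3)cnn2CC#N)c1` differs from compound 1 in one place only: dimethylamino in place of acetyl on an aromatic carbon. Among the measured compounds shown here, no measured step shows what this change alone does. Still, compound 3 is expected to give a lower number than compound 1, a step of a number 51 percentage points lower from compound 1 to compound 3 (beyond the scatter), because compound 2, which carries the same dimethylamino group, gives 14%. The estimate for compound 3 is 35%, with a range from 10% to 75%.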

Compound 3, a percentage reported as activity, at one concentration (the size of the read-out at that concentration, not a potency): -21%
The estimate for compound 3 lay 56 percentage points above the measured number; measured number below the stated range.
By their numbers in this assay, from the lowest: compound 3; then compound 2; then compound 1.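

Replacing acetyl with dimethylamino on this aromatic carbon, para to a large group, gives a number 107 percentage points lower from compound 1 to compound 3 (beyond the scatter) in this assay, so this one position on its own has a large influence on the read-out. Compound 3 even reaches -21%, a number under zero. Acetyl and dimethylamino match in heavy atoms, hydrogen-bond donors and acceptors, so these counts do not separate the two groups, and no measurement here explains the step.

The compounds shown leave open whether dimethylamino is special or whether other nitrogen groups, such as a primary amine or morpholine, would give a similarly low number at this position. They also leave open where a methoxy group or a carboxylic acid in the same place would fall between compound 1 and compound 3.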